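Replacing the anilide of compound 3 with a dimethylaminoethyl amide

The compounds below may be only part of what the source reports. "The series", "measured", "known", "first", "only" and "open" are said of these compounds alone.

Compound 3 `COc1ccc(NC(=O)CCC(=O)OCCCCCCSc2ccc([N+](=O)[O-])c3nonc23)cc1` gives the lowest number of the three measured compounds in an assay on isolated protein for inhibition of glutathione S-transferase Mu 2 (Homo sapiens), with a stated time of 10 min (a higher number here means a weaker inhibitor, a lower number a stronger inhibitor), at 130 nM. Compound 1 `O=C(CCC(=O)OCCCCCCSc1ccc([N+](=O)[O-])c2nonc12)Nc1ccccc1` gives 700 nM and compound 2 `O=C(CCC(=O)OCCCCCCSc1ccc([N+](=O)[O-])c2nonc12)Nc1ccccc1F` gives 350 nM; the measured steps read a 5.4-fold lower number from compound 1 to compound 3 (0.73 log units; beyond the scatter), a 2.7-fold lower number from compound 2 to compound 3 (0.43 log units; beyond the scatter) and a 2.0-fold lower number from compound 1 to compound 2 (0.30 log units; within the scatter). Compound 4 `CN(C)CCNC(=O)CCC(=O)OCCCCCCSc1ccc([N+](=O)[O-])c2nonc12` differs from compound 3 by 2-(dimethylamino)ethyl in place of 4-methoxyphenyl on an amide-type nitrogen. Within the data shown here, all three measured compounds keep an aromatic ring on that amide nitrogen, so no measured step bears directly on this change; they show only that small changes on that ring shifted the number modestly. The expected step is therefore uncertain and guessed as a weakening, a 4.6-fold higher number from compound 3 to compound 4 (0.66 log units; beyond the scatter). Compound 4 is estimated at 600 nM, with a range from 150 nM to 2500 nM.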

Compound 4, half-maximal inhibitory concentration: 160 nM
Compound 4: middle estimate off by 3.8-fold (0.57 log units), on the high side; the measured number falls inside the stated range.
By their numbers in this assay, from the lowest: compounds 3 and 4 (each within the scatter of the next); then compounds 2 and 1 (each within the scatter of the next).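

In this assay, an amide nitrogen carrying 2-(dimethylamino)ethyl, with no ring, cannot be told apart from one carrying 4-methoxyphenyl: a 1.2-fold higher number from compound 3 to compound 4 (0.09 log units; within the scatter). An aromatic ring on this nitrogen is therefore not needed for a number of this size, and the ringless group also compares well with the 2-fluorophenyl and phenyl groups: a 2.2-fold lower number from compound 2 to compound 4 (0.34 log units; beyond the scatter), and a 4.4-fold lower number from compound 1 to compound 4 (0.64 log units; beyond the scatter). Nothing at hand explains this result.

From the compounds shown here alone, whether the dimethylamino nitrogen itself matters remains open. A plain butyl chain, a 2-hydroxyethyl group, or a longer chain ending in the same amine on this nitrogen would begin to separate the amine from the chain.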